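Alkyl Swap on the Alkyne of a Shared Core

A few compounds are considered here, and "the series" means these few. Any claim that something is new, unique, unknown or untested is made for them only; others in the source may bear on it.

Measured compounds:
compound 1, `CC(=O)OCC(CCn1cc(C#Cc2cc(F)cc(F)c2)c(=O)n(C(=O)c2ccccc2)c1=O)COC(C)=O`, 46600 nM
compound 2, `CCCCCCCCC#Cc1cn(CCC(COC(C)=O)COC(C)=O)c(=O)n(C(=O)c2ccccc2)c1=O`, > 100000 nM

The two measured compounds share one core and differ only in the group on the triple-bonded carbon. In an ADME assay on BJ cells (Homo sapiens) for antiproliferative activity, read by MTT assay, with a stated time of 72 h (on this read-out higher numbers stand for weaker inhibition and lower numbers for stronger inhibition), compound 1 gives 46600 nM. Compound 2 reaches only a limit in this assay, > 100000 nM, so its standing is a bound rather than a number, as noted in the limit of > 100000 nM in this assay, at which 1 of the 2 values shown sits. For the measured compounds named here, the sole measured step is an at least 2.1-fold higher number from compound 1 to compound 2 (0.33 log units; beyond the scatter).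

Compound 3, `CC(=O)OCC(CCn1cc(C#CC(C)(C)C)c(=O)n(C(=O)c2ccccc2)c1=O)COC(C)=O`, differs from compound 2 by tert-butyl in place of octyl on a triple-bonded carbon. Going by the values given here, no measured step covers an exchange of one alkyl group for another; the one known step, from an aryl group to octyl, moved the number upward to the limit. The step of an at least 1.1-fold lower number from compound 2 to compound 3 (0.04 log units; that floor lies within the scatter) is therefore expected to be small. Compound 3 is expected to stay near the limit, estimated at 90000 nM, within a range from 35000 nM to 250000 nM.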

Compound 3, half-maximal inhibitory concentration: 36900 nM
Compound 3: the middle estimate sits 2.4-fold (0.39 log units) above what was measured; the measured number falls inside the stated range.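

In this assay, the choice of alkyl group on the triple-bonded carbon matters: the exchange of octyl for tert-butyl gives an at least 2.7-fold lower number from compound 2 to compound 3 (0.43 log units; beyond the scatter), so the earlier upward step cannot be read as something all alkyl groups share at this position. Set against the aryl group, tert-butyl gives a 1.3-fold lower number from compound 1 to compound 3 (0.10 log units; within the scatter), so a group without a ring stands level with 3,5-difluorophenyl here, and a ring is not required for a number of this size. Compound 2 alone stands at a limit, so the step away from it has only a floor: the limit of > 100000 nM in this assay, at which 1 of the 3 values shown sits.

On these data alone, whether the step from octyl follows chain length or branching stays open, as tert-butyl and octyl differ in both. As far as these compounds go, how a straight butyl chain, or a chain ending in an amine, would read on this triple-bonded carbon also remains open.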